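Replacing a hydroxymethyl chain with an all-carbon chain

The source may report more compounds than this note shows. Statements on the series, on what has been measured and on what is new or still open speak of the compounds shown alone.

Values in a functional assay on HeLa cells (Homo sapiens) for cytotoxicity, read by WST assay, with a stated time of 48 h; a lower number here means a stronger inhibitor, a higher number a weaker inhibitor:
Compound 1 `COc1cc(C(c2ccc(O)c(OC)c2)[C@H](C)[C@H](C)CO)ccc1O`: > 100000 nM (a limit)
Compound 2 `COc1cc(C(c2ccc(O)c(OC)c2)[C@@H](C)[C@@H](C)CF)ccc1O`: 42000 nM
Compound 3 `COc1cc(C(c2ccc(O)c(OC)c2)[C@@H](C)[C@H](C)CO)ccc1O`: > 100000 nM (a limit)

In this assay compound 3 stands at > 100000 nM, which is only a limit and not a number. Compound 4 `CCCCC[C@H](C(C)C)C(c1ccc(O)c(OC)c1)c1ccc(O)c(OC)c1` differs from it in one place: 1-isopropylhexyl in place of 2-(hydroxymethyl)-1-methylpropyl on a saturated chain carbon bound to two aromatic carbons. The oxygen-bearing chain gives way to 1-isopropylhexyl, on a saturated chain carbon bound to two aromatic carbons. The nearest measured change is fluoromethyl in place of hydroxymethyl, which gave an at least 2.3-fold lower number from compound 1 to compound 2 (0.37 log units; beyond the scatter). Its counterpart, hydroxymethyl in place of fluoromethyl, gave an at least 2.3-fold higher number from compound 2 to compound 3 (0.37 log units; beyond the scatter). On those two steps, a modest move to a lower number is expected, though the new chain is far larger and the uncertainty is wide. The estimated step is an at least 3.3-fold lower number from compound 3 to compound 4 (0.52 log units; beyond the scatter). For compound 4 the expected value is 30000 nM, with an estimated range of 7000 nM to 100000 nM.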

Compound 4, half-maximal inhibitory concentration: 9200 nM
Compound 4: the middle estimate sits 3.3-fold (0.51 log units) above what was measured; measured number inside the range.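

On the saturated chain carbon bound to two aromatic carbons, 1-isopropylhexyl gives an at least 10-fold lower number from compound 3 to compound 4 (1.03 log units; beyond the scatter) and an at least 10-fold lower number from compound 1 to compound 4 (1.03 log units; beyond the scatter) in this assay. A chain without oxygen therefore gives a measured value, where both hydroxymethyl chains reach only a limit. Among the compounds shown here, it also outdoes the fluoromethyl chain, with a 4.6-fold lower number from compound 2 to compound 4 (0.66 log units; beyond the scatter), the only step here with a number at both ends.

These compounds do not separate the loss of the oxygen from the change to a larger chain. On these data alone, the effect of an amine on this chain also stays open. The full size of the steps from the hydroxymethyl compounds also stays unknown: the limit of > 100000 nM in this assay, at which 2 of the 4 values shown sit.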